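Swapping Chloro for Methyl on the Core of Compound 1

The source may report more compounds than this note shows. Statements on the series, on what has been measured and on what is new or still open speak of the compounds shown alone.

Compound 1 `Cc1cc(C)nc(SCc2cc(=O)c3cc(Cl)ccc3o2)n1` was tested in a functional assay on MCF7 cells (Homo sapiens) for cytotoxicity, read by MTT assay, with a stated time of 72 h; a higher number here means a weaker inhibitor, a lower number a stronger inhibitor. In this assay compound 1 gives > 25000 nM, which is a limit of the assay rather than a number. Compound 3 `Nc1nnc(SCc2coc3ccccc3c2=O)s1` also reaches only a limit, giving > 25000 nM in this assay. Compound 1 therefore stands at the limit of > 25000 nM in this assay, at which 2 of the 3 values shown sit. Compound 2 `Cc1nnc(SCc2coc3ccccc3c2=O)o1` gives 4600 nM in this assay, and the step of an at least 5.4-fold higher number from compound 2 to compound 3 (0.73 log units; beyond the scatter) concerns a different part of the molecule than the one considered here. Compound 4 `Cc1ccc2oc(CSc3nc(C)cc(C)n3)cc(=O)c2c1` differs from compound 1 by methyl in place of chloro on an aromatic carbon. For the measured compounds named here, no measured step touches this position, so the direction of any change is unknown. Since compound 1 rests at the limit of > 25000 nM in this assay, at which 2 of the 3 values shown sit, compound 4 is expected to show a step that the limit leaves unreadable from compound 1 to compound 4. Compound 4 is estimated at 30000 nM, within a range from 8000 nM to 100000 nM.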

Compound 4, half-maximal inhibitory concentration: > 25000 nM
Compound 4 was reported as a limit; the forecaster's own chance of this, stated with the estimate: 70%; the middle value lies beyond the limit too.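

In this assay compound 4 gives > 25000 nM, which is a limit and not a number. Compound 1 also rests at a limit, so no step between compound 1 and compound 4 can be read: the limit of > 25000 nM in this assay, at which 3 of the 4 values shown sit.

From the compounds shown here alone, whether methyl or chloro on this aromatic carbon gives the stronger inhibitor remains open.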